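The source may report more compounds than this note shows. Statements on the series, on what has been measured and on what is new or still open speak of the compounds shown alone.

Compound 1 `CCCCCC(CCCCC)c1nc(-c2ccc(F)cc2)c[nH]1`: 770 nM
Compound 2 `CCCCCCc1nc(-c2ccc(CC(C)C)cc2)c[nH]1`: 380 nM

For the measured compounds named here, in a functional assay on SH-SY5Y cells (Homo sapiens) for cytotoxicity (on this read-out lower numbers stand for stronger inhibition and higher numbers for weaker inhibition), compound 1 gives 770 nM, the higher of the two numbers so far, and therefore the weaker inhibition. Compound 2 gives 380 nM, and that gap lies just beyond the usual scatter of repeated measurements. The two compounds differ in more than one place, so their values cannot show what any single change does.

The next compound to be tested is compound 3 `CCCCCC(CCCCC)c1nc(-c2ccc(-c3ccccc3)cc2)c[nH]1`. It keeps the core and the long branched chain of compound 1 and changes one group: phenyl in place of fluoro on an aromatic carbon. In words, phenyl takes the place of fluoro on an aromatic carbon, para to a large group. Going by the values given here, this is a large increase in size at that spot, and no measured pair shows what such a swap does in this assay.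

The expected change is a 1.5-fold lower number from compound 1 to compound 3 (0.19 log units; within the scatter), a modest move towards stronger inhibition, held with little confidence. For compound 3 the estimated value is 500 nM, with an expected range from 150 nM to 1600 nM.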

Compound 3, half-maximal inhibitory concentration: 810 nM
The estimate for compound 3 lay 1.6-fold (0.21 log units) below the measured number; low and high end bracket the measured number.
By their numbers in this assay, from the lowest: compound 2; then compounds 1 and 3 (each within the scatter of the next).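

In this assay, placing phenyl in place of fluoro on an aromatic carbon, para to a large group, gives a 1.1-fold higher number from compound 1 to compound 3 (0.02 log units; within the scatter), so the two numbers cannot be told apart. For the compounds shown here, this is the first comparison here that differs in only one place: with the core and the long branched chain held the same, a group of 6 heavy atoms, including a whole six-membered aromatic ring, gives a result that matches that of a single fluorine atom, at least for this one pair. Nothing measured alongside these compounds speaks to why the two numbers match.

Compound 2 differs from compound 1 and from compound 3 in more than one place, so it remains unclear which of its features goes with its separate number. On these data alone, it also remains open whether this match would hold for other groups at the same spot, such as an amine or a carboxylic acid, which would bring hydrogen-bonding atoms or charge to a place where fluoro and phenyl have neither.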